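The source may hold more compounds than are shown below. What is called first, only, known or untested is meant among the compounds shown, and "the series" means these compounds.

Compound 1 `COc1ccc2[nH]c(-c3ccccc3)c(C=C(C#N)C#N)c2c1`: 4200 nM
Compound 2 `CC(=O)/C(=C\c1c(-c2ccccc2)[nH]c2ccccc12)S(=O)(=O)c1ccccc1`: 2400 nM

Both were tested in a functional assay on SF-295 cells (Homo sapiens) for inhibition, read by sulforhodamine B assay, with a stated time of 48 h; on this read-out lower numbers stand for stronger inhibition of growth and higher numbers for weaker inhibition of growth. Compound 2 gives the lowest of the two numbers, but its gap to compound 1 lies within the scatter, so the two cannot be told apart on these data. Compound 3 `N#C/C(=C\c1c(-c2ccccc2)[nH]c2ccccc12)S(=O)(=O)c1ccccc1` has not been measured. It differs from compound 2 in one place: cyano in place of acetyl on a double-bonded chain carbon bound to a double-bonded chain carbon and a sulfonyl sulfur. For the measured compounds named here, no pair of measured compounds shows this exchange, so the size of the step can only be guessed. Compound 1, which also carries cyano and gives 4200 nM, lies close to compound 2, which suggests that a cyano group at this kind of place does not move the read-out far. The expected step is therefore small, in no sure direction, and probably within the scatter: a 1.3-fold higher number from compound 2 to compound 3 (0.10 log units; within the scatter). Compound 3 is estimated at 3000 nM, with a likely range from 1200 nM to 8000 nM.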

Compound 3, concentration for 50% growth inhibition: 2400 nM
The estimate for compound 3 lay 1.3-fold (0.10 log units) above the measured number, and the stated range covers the measured number.
By their numbers in this assay, from the lowest: compounds 2, 3 and 1 (each within the scatter of the next).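

For the compounds shown here, this is the first direct reading of a single exchange at this spot: in this assay, putting cyano in place of acetyl on a double-bonded chain carbon bound to a double-bonded chain carbon and a sulfonyl sulfur gives no change at the digits printed from compound 2 to compound 3 (within the scatter). The read-out therefore does not separate these two groups, although cyano has 2 heavy atoms and a triple bond while acetyl has 3 heavy atoms and a double bond, and each counts 1 hydrogen-bond acceptor. Nothing available explains why the two groups read alike.

On these data alone, whether this tolerance extends to other groups remains open, since a carboxylic acid, an amine or a longer chain at this carbon could behave differently. The same exchange on other cell types also remains an open question.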